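Halogenated thioacrylic acids as calpain-1 inhibitors: notes

A few compounds are considered here, and "the series" means these few. Any claim that something is new, unique, unknown or untested is made for them only; others in the source may bear on it.

Measured so far:
compound 1 `O=C(O)/C(S)=C/c1c[nH]c2ccc(F)cc12` — 800 nM
compound 2 `O=C(O)/C(S)=C/c1ccc(Br)cc1` — 1500 nM
compound 3 `O=C(O)/C(S)=C/c1c[nH]c2c(I)cccc12` — 90 nM

All three were read in an assay on isolated protein for inhibition of Calpain-1 catalytic subunit (Sus scrofa), read by FRET; on this read-out lower numbers stand for stronger inhibition and higher numbers for weaker inhibition. Compound 1 has the second highest of the three numbers. Its nearest neighbour is compound 2, whose number is higher, though the gap between the two lies within the scatter, so no order between compound 1 and compound 2 can be claimed. Compound 3 stands furthest away, with a lower number, and that gap is beyond the scatter.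

The next member, compound 4 `O=C(O)/C(S)=C/c1c[nH]c2ccc(Cl)cc12`, has not yet been measured. It differs from compound 1 in one place: chloro in place of fluoro on an aromatic carbon. Among the compounds with values here, no measured pair in this set shares this particular change, so the expectation rests on the halogen series as a whole, where compound 3 with iodo gives 90 nM against compound 1 with fluoro at 800 nM. A modest downward step is expected, a 1.6-fold lower number from compound 1 to compound 4 (0.20 log units; within the scatter), likely within or close to the scatter. For compound 4 the estimated value in this assay is 500 nM, with a range from 150 nM to 1500 nM.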

Compound 4, half-maximal inhibitory concentration: 250 nM
Compound 4: the middle estimate sits 2.0-fold (0.30 log units) above what was measured; the range from low to high includes it.
By their numbers in this assay, from the lowest: compound 3; then compound 4; then compounds 1 and 2 (each within the scatter of the next).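

Within the data shown here, this is the first step that can be read from a single change: on an aromatic carbon of the six-membered ring, meta to a fused ring and para to a fused ring, chloro in place of fluoro gives a 3.2-fold lower number from compound 1 to compound 4 (0.51 log units; beyond the scatter) in this assay. Among these compounds, with the rest of the structure held fixed, the identity of the halogen at this carbon therefore moves the read-out by more than the scatter, which the earlier compounds, none differing in one place only, could not show. Nothing at hand accounts for the step.

From the compounds shown here alone, whether bromo or iodo at this same carbon would extend the step or reverse it remains open, as does the outcome with a non-halogen group such as methyl, methoxy or an amine. A single pair also cannot show whether chloro in place of fluoro would give a similar step at another carbon of the core.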